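The source may hold more compounds than are shown below. What is called first, only, known or untested is meant among the compounds shown, and "the series" means these compounds.

In a functional assay on U2OS cells (Homo sapiens) for antiproliferative activity, read by MTT assay, with a stated time of 72 h (a higher number here means a weaker inhibitor, a lower number a stronger inhibitor), compound 2 `Cc1cc(C)cc(C(=O)Nc2nc3ccc(NC(=O)CSc4ccc(Cl)cc4)cc3s2)c1` reaches only a limit, > 100000 nM, and not a number. So the measurement gives no exact potency for compound 2, and it stands as the only compound here without one. Compound 3 `O=C(CSc1ccc(Cl)cc1)Nc1ccc2nc(NC(=O)c3ccc(C(F)(F)F)cc3)sc2c1` differs from compound 2 in a single place, where 4-(trifluoromethyl)phenyl takes the place of 3,5-dimethylphenyl on a carbonyl carbon: 4-(trifluoromethyl)phenyl in place of 3,5-dimethylphenyl on a carbonyl carbon. Among the compounds with values here, the one other measured compound, compound 1 `Cc1ccc(SCC(=O)Nc2ccc3nc(NC(=O)c4ccc(C(F)(F)F)cc4)sc3c2)c(C)c1`, also carries 4-(trifluoromethyl)phenyl on a carbonyl carbon, and in this assay compound 1 gives 1000 nM. Within the data shown here, with that value as the only guide, a large gain in potency is expected, meaning a fall in the number well beyond the usual scatter. The estimated change is an at least 33-fold lower number from compound 2 to compound 3 (1.52 log units; beyond the scatter). For compound 3 the expected value is 3000 nM, with an estimated range from 500 nM to 40000 nM.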

Compound 3, half-maximal inhibitory concentration: 2890 nM
Beside the measured number, compound 3's estimate is 1.0-fold (0.02 log units) above it; the range from low to high includes it.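

In this assay, the group on the carbonyl carbon now has a readable effect in a pair that differs in that one place: with 4-chlorophenyl on the sulfur in both compounds, 4-(trifluoromethyl)phenyl in place of 3,5-dimethylphenyl gives an at least 34-fold lower number from compound 2 to compound 3 (1.53 log units; beyond the scatter) and marks this position as highly sensitive to the change. Compound 2 stands at a limit of the assay and not at a number, so this step has a floor but no exact size: the limit of > 100000 nM in this assay, at which 1 of the 3 values shown sits. The group on the sulfur also counts, though far less clearly, since 4-chlorophenyl in place of 2,4-dimethylphenyl gives a 2.9-fold higher number from compound 1 to compound 3 (0.46 log units; beyond the scatter) with 4-(trifluoromethyl)phenyl on the carbonyl carbon in both compounds.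

Still open, from the compounds shown here alone, is how a plain phenyl, or a phenyl carrying a methoxy group or a carboxylic acid, would fare on the carbonyl carbon. Also open, going by these compounds, is whether the large step holds with 2,4-dimethylphenyl on the sulfur.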